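The source may hold more compounds than are shown below. What is called first, only, known or untested is meant among the compounds shown, and "the series" means these compounds.

Values in a functional assay on U-87MG ATCC cells (Homo sapiens) for cytotoxicity, read by MTT assay, with a stated time of 48 h; on this read-out lower numbers stand for stronger inhibition and higher numbers for weaker inhibition:
- compound 1 `C/C(=N\NC(=S)Nc1ccccc1I)c1ccccn1`: 6.1 nM
- compound 2 `CC(=NNC(=S)Nc1cccc([N+](=O)[O-])c1)c1ccccn1`: 69 nM

Compound 2 has the higher of the two numbers, and its gap to compound 1 lies beyond the scatter. Compound 3 `CC(=NNC(=S)Nc1ccccc1)c1ccccn1` has hydrogen in place of nitro on an aromatic carbon. For the measured compounds named here, no measured step isolates this change. Compound 1, at 6.1 nM, also carries no nitro, so a modest move toward lower numbers in this assay is expected, possibly not beyond the scatter. The expected step is a 1.7-fold lower number from compound 2 to compound 3 (0.24 log units; within the scatter). For compound 3 the estimated value is 40 nM, with an expected range of 8 nM to 150 nM.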

Compound 3, half-maximal inhibitory concentration: 1.4 nM
Compound 3: middle estimate off by 29-fold (1.46 log units), on the high side; the whole stated range lies above it.
By their numbers in this assay, from the lowest: compound 3; then compound 1; then compound 2.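

Hydrogen in place of nitro on an aromatic carbon, meta to a large group, gives a 49-fold lower number from compound 2 to compound 3 (1.69 log units; beyond the scatter) in this assay. The read-out at this position therefore depends strongly on the group it carries, and of the two groups compared here, hydrogen gives the lower number. No measured data bear on the reason for this step. 

From the compounds shown here alone, whether an amine or a methoxy group on the same carbon would read closer to compound 3 or to compound 2 remains open. Also open, going by these compounds, is whether a smaller step would follow from a fluorine there.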